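Replacing the carboxylic acid of compound 2 with an alcohol

This account rests on a few compounds, and the source may have more. Where it says the series, first, only, none or still open, it means among the compounds named here.

In a functional assay on MCF7 cells (Homo sapiens) for antiproliferative activity, read by sulforhodamine B assay, with a stated time of 72 h (a lower number here means a stronger inhibitor, a higher number a weaker inhibitor), compound 2 `COc1ncc(-c2ccc3ncnc(Nc4cnn(CCC(=O)O)c4)c3c2)cc1NS(C)(=O)=O` gives 560 nM, the lowest of the two numbers recorded. Compound 1 `COc1ncc(-c2ccc3ncnc(Nc4ccc(OCCO)cc4)c3c2)cc1NS(=O)(=O)c1ccc(F)cc1F` gives 1650 nM, a gap that lies beyond the usual scatter. For compound 3 `CCCCS(=O)(=O)Nc1cc(-c2ccc3ncnc(Nc4ccc(OCCO)nc4)c3c2)cnc1OC` the this assay reports only a limit, > 20000 nM, and this is the limit of > 20000 nM in this assay, at which 1 of the 3 values shown sits. Compound 4 `COc1ncc(-c2ccc3ncnc(Nc4cnn(CCCO)c4)c3c2)cc1NS(C)(=O)=O` differs from compound 2 by a single change: hydroxymethyl in place of carboxy on a saturated chain carbon, two bonds along the chain from an aromatic nitrogen. Among the measured compounds shown here, no measured pair shows this change, so its effect is not known from the data. For compound 4 the step of a 1.2-fold lower number from compound 2 to compound 4 (0.09 log units; within the scatter) is expected to be small and not beyond the scatter. Compound 4 is therefore estimated at 450 nM in the this assay, within a range from 150 nM to 1500 nM.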

Compound 4, half-maximal inhibitory concentration: 730 nM
For compound 4 the middle estimate is 1.6-fold (0.21 log units) below the measured one; measured number inside the range.
By their numbers in this assay, from the lowest: compounds 2 and 4 (each within the scatter of the next); then compound 1. At a limit, above all of these: compound 3.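

In this assay, among the compounds shown here, hydroxymethyl in place of carboxy on a saturated chain carbon, two bonds along the chain from an aromatic nitrogen, gives a 1.3-fold higher number from compound 2 to compound 4 (0.12 log units; within the scatter) as the first step at this position. On this core, then, the 2-carboxyethyl and 3-hydroxypropyl groups cannot be told apart, so the carboxy group is not required for activity at this level. Nothing measured here accounts for this similarity. The compounds shown leave open whether an amine or a primary amide at the chain end would also stay within the scatter of compound 2. They also leave open how a shorter or longer chain would read.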